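Ester side-chain variation on the shared core

The source may report more compounds than this note shows. Statements on the series, on what has been measured and on what is new or still open speak of the compounds shown alone.

Compound 1 `C/C=C1/[C@H](O[C@@H]2O[C@H](CO)[C@@H](O)[C@H](O)[C@H]2O)OC=C(C(=O)OC)[C@H]1CC(=O)OCCc1ccc(O)c(O)c1` in a functional assay on SK-BR-3 cells (Homo sapiens) for antiproliferative activity, read by MTT assay, with a stated time of 72 h (a lower number here means a stronger inhibitor, a higher number a weaker inhibitor), gives 160000 nM. Compound 2 `C/C=C1/[C@H](O[C@@H]2O[C@H](CO)[C@@H](O)[C@H](O)[C@H]2O)OC=C(C(=O)OC)[C@H]1CC(=O)OC` in this assay reaches only a limit, > 15000 nM. Compound 3 `C/C=C1/[C@H](O[C@@H]2O[C@H](CO)[C@@H](O)[C@H](O)[C@H]2O)OC=C(C(=O)OC)[C@H]1CC(=O)OCCc1ccc2c(c1)OCCO2` in this assay likewise reaches only a limit, > 20000 nM.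

Compound 3 thus stands at a limit, and among the three values shown it is one of two that are limits rather than numbers. The steps a step that the limit leaves unreadable from compound 1 to compound 2, a step that the limit leaves unreadable from compound 1 to compound 3 and a step that the two limits leave unreadable from compound 2 to compound 3 cannot be sized because of the limit of > 15000 nM in this assay, at which 1 of the 3 values shown sits, and (the limit of > 20000 nM in this assay, at which 1 of the 3 values shown sits). Compound 4 `C/C=C1/[C@H](O[C@@H]2O[C@H](CO)[C@@H](O)[C@H](O)[C@H]2O)OC=C(C(=O)OC)[C@H]1CC(=O)OCCC(C)C` differs from compound 3 by isopropyl in place of 2,3-dihydro-1,4-benzodioxin-6-yl on a saturated chain carbon, two bonds along the chain from an oxygen next to a carbonyl group. Going by the values given here, no measured step bears readably on this change. No step beyond the scatter is expected here, so a step that the limit leaves unreadable from compound 3 to compound 4 is the estimated step, and compound 4 is expected at 30000 nM (range 10000 nM to 150000 nM), most probably reported only as a limit again.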

Compound 4, half-maximal inhibitory concentration: 9020 nM
The estimate for compound 4 lay 3.3-fold (0.52 log units) above the measured number; measured number below the stated range.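

In this assay, at this place on a saturated chain carbon, two bonds along the chain from an oxygen next to a carbonyl group, isopropyl in place of 2,3-dihydro-1,4-benzodioxin-6-yl gives an at least 2.2-fold lower number from compound 3 to compound 4 (0.34 log units; beyond the scatter), and isopropyl in place of 3,4-dihydroxyphenyl gives an 18-fold lower number from compound 1 to compound 4 (1.25 log units; beyond the scatter), so an aromatic ring on this chain is not needed for the activity seen here. Isobutyl in place of hydrogen gives an at least 1.6-fold lower number from compound 2 to compound 4 (0.22 log units; that floor lies within the scatter), a floor that leaves this comparison unsettled. The steps among compound 1, compound 2 and compound 3 cannot be read.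

Going by these compounds, it remains open whether the lower number follows from the branched chain or from the absence of the aromatic ring. A longer chain such as n-hexyl, or a cyclohexyl group, at this place would separate the two.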